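Carbonyl substituent swap on the shared aminothienopyrimidine-free core

The source may report more compounds than this note shows. Statements on the series, on what has been measured and on what is new or still open speak of the compounds shown alone.

Measured so far:
Compound 1 `CC(=O)Nc1ccc(-c2nc(N3CC4CCC(C3)O4)c3sccc3n2)cc1` — 1700 nM
Compound 2 `O=C(Nc1ccncc1)Nc1ccc(-c2nc(N3CC4CCC(C3)O4)c3sccc3n2)cc1` — 10 nM

Among the compounds with values here, in a functional assay on LNCaP cells (Homo sapiens) for cytotoxicity (on this read-out lower numbers stand for stronger inhibition and higher numbers for weaker inhibition), compound 2 gives 10 nM, the lowest of the two numbers recorded; the only neighbour is compound 1, which gives 1700 nM in this assay. Within the data shown here, the single measured step, a 170-fold lower number from compound 1 to compound 2 (2.23 log units; beyond the scatter), turns entirely on what sits on the carbonyl carbon of the anilide, so that step is the one that bears on the present change.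

Compound 3 `COC(=O)Nc1ccc(-c2nc(N3CC4CCC(C3)O4)c3sccc3n2)cc1` differs from compound 2 by methoxy in place of (pyridin-4-yl)amino on a carbonyl carbon. This removes the (pyridin-4-yl)amino group whose arrival produced the large gain, and puts in its place a small group without a ring or a hydrogen-bond donor, much as in compound 1. The expectation is therefore a loss roughly mirroring the measured step, a 100-fold higher number from compound 2 to compound 3 (2.00 log units; beyond the scatter), since compound 1 with 1700 nM shows where a small carbonyl substituent lands on this core. Compound 3 is estimated at 1000 nM, with a plausible range from 250 nM to 4000 nM.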

Compound 3, half-maximal inhibitory concentration: 1850 nM
Beside the measured number, compound 3's estimate is 1.9-fold (0.27 log units) below it; measured number inside the range.
By their numbers in this assay, from the lowest: compound 2; then compounds 1 and 3 (each within the scatter of the next).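

In this assay, methoxy in place of (pyridin-4-yl)amino on a carbonyl carbon gives a 190-fold higher number from compound 2 to compound 3 (2.27 log units; beyond the scatter) and so removes the whole of the advantage held by compound 2, which shows that a carbonyl carbon bearing an oxygen-linked small group does not retain it. Methoxy in place of methyl at the same carbon gives a 1.1-fold higher number from compound 1 to compound 3 (0.04 log units; within the scatter) with no separation between the two small groups, so on the shared core the low number so far belongs to compound 2 alone. No supporting measurement bears on the origin of these differences.

The change from (pyridin-4-yl)amino to methoxy removes the ring and the hydrogen-bond donor together, so the compounds shown do not tell which of these features, or the ring nitrogen itself, goes with the low number. Phenylamino or methylamino on the same carbonyl carbon would separate these features, and whether either holds the low number of compound 2 remains open.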